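The source may hold more compounds than are shown below. What is called first, only, known or untested is meant among the compounds shown, and "the series" means these compounds.

Compound 1 `CN(C)C(=O)c1cc2cnc(Nc3ccc(NC(=O)C4(C(=O)Nc5ccc(F)cc5)CC4)cc3F)nc2n1C1CCCC1`: 6.3%
Compound 2 `CN(C)C(=O)c1cc2cnc(Nc3ccc(NC(=O)C4(C(=O)Nc5ccc(Cl)c(C(F)(F)F)c5)CC4)cc3)nc2n1C1CCCC1`: 6.9%
Compound 3 `CN(C)C(=O)c1cc2cnc(Nc3ccc(NC(=O)C4(C(=O)Nc5cccc(C(F)(F)F)c5)CC4)cc3)nc2n1C1CCCC1`: 9.7%

In a functional assay on T47D cells (Homo sapiens) for inhibition, read by CCK-8 assay, with a stated time of 72 h, tested at 1 uM (a lower number here means less inhibition of growth, a higher number more inhibition of growth at the concentration tested), compound 2 gives 6.9%. Its number sits between the other two: compound 1 gives 6.3% and compound 3 gives 9.7%, and both gaps to compound 2 lie within the scatter. All three anilides, whatever their aryl substitution, give low growth inhibition at the concentration tested.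

Compound 4 `Cc1cccc(NC(=O)C2(C(=O)Nc3ccc(Nc4ncc5cc(C(=O)N(C)C)n(C6CCCC6)c5n4)cc3)CC2)c1` differs from compound 2 by 3-methylphenyl in place of 4-chloro-3-(trifluoromethyl)phenyl on an amide-type nitrogen. Among the measured compounds shown here, the only measured step that bears on this position is a number 2.8 percentage points higher from compound 2 to compound 3 (within the scatter), where a hydrogen replaced a chloro on an aromatic carbon and nothing beyond the scatter followed. Compound 1, which differs from compound 2 at more than one place, also stays in the same low region. Nothing measured here suggests that the anilide aryl group moves this assay.

A step of a number 1.1 percentage points higher from compound 2 to compound 4 (within the scatter) is therefore expected, not beyond the scatter. Compound 4 is estimated at 8%, with a range from 0% to 18%.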

Compound 4, percent growth inhibition at one concentration: 45.7%
Estimate against measurement, compound 4: 37.7 percentage points below; the whole stated range lies below it.
By their numbers in this assay, from the lowest: compounds 1, 2 and 3 (each within the scatter of the next); then compound 4.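

The aryl group on the amide-type nitrogen does move the read-out in this assay and the change to 3-methylphenyl from 4-chloro-3-(trifluoromethyl)phenyl gives a number 38.8 percentage points higher from compound 2 to compound 4 (beyond the scatter) on the shared core. With methyl in place of trifluoromethyl on an aromatic carbon the step is a number 36 percentage points higher from compound 3 to compound 4 (beyond the scatter) while hydrogen in place of chloro gave only a number 2.8 percentage points higher from compound 2 to compound 3 (within the scatter) so among these compounds the exchange of trifluoromethyl for methyl is the change that counts. Nothing shown gives a cause for this step.

Going by these compounds, whether the methyl itself is needed, or only the loss of trifluoromethyl, stays open. So does how a methoxy group, an amino group or a longer alkyl chain on that aromatic carbon would read.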